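This account rests on a few compounds, and the source may have more. Where it says the series, first, only, none or still open, it means among the compounds named here.

Compound 1 `COc1cc(-c2nn(-c3cccc(NC(=O)c4cccc(C(F)(F)F)c4)c3)cc2-c2ccncc2)ccc1Cl` and compound 2 `COc1cc(-c2nn(-c3cccc(NC(=O)c4ccc(Cl)c(C(F)(F)F)c4)c3)cc2-c2ccncc2)ccc1Cl` share one core and differ in a single place. In a functional assay on Hs-578T cells (Homo sapiens) for inhibition, read by sulforhodamine B assay, with a stated time of 48 h (a higher number here means a weaker inhibitor of growth, a lower number a stronger inhibitor of growth), compound 1 gives 1070 nM, while compound 2 gives 2170 nM. Going by the values given here, the only measured step, a 2.0-fold higher number from compound 1 to compound 2 (0.31 log units; beyond the scatter), is a chloro in place of hydrogen on an aromatic carbon; compound 2 therefore stands at the highest of the two numbers and is the weaker of the pair. Compound 3 `COc1cc(-c2nn(-c3cccc(NC(=O)Nc4ccc(Cl)c(C(F)(F)F)c4)c3)cc2-c2ccncc2)ccc1Cl` changes compound 2 elsewhere: (4-chloro-3-(trifluoromethyl)phenyl)amino in place of 4-chloro-3-(trifluoromethyl)phenyl on a carbonyl carbon. Among the compounds with values here, no measured step bears on this kind of exchange, because the step from compound 1 to compound 2 concerns an aromatic substituent and says nothing about the carbonyl. The expectation for this assay thus rests on the value of compound 2 alone, with a wide range and no direction beyond the scatter. Compound 3 is estimated at 1800 nM, between 500 nM and 6500 nM. This corresponds to an expected step of a 1.2-fold lower number from compound 2 to compound 3 (0.08 log units; within the scatter).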

Compound 3, concentration for 50% growth inhibition: 1320 nM
Beside the measured number, compound 3's estimate is 1.4-fold (0.13 log units) above it; the range from low to high includes it.
By their numbers in this assay, from the lowest: compounds 1, 3 and 2 (each within the scatter of the next, the first and the last beyond it).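

Putting an amino group between the carbonyl carbon and the 4-chloro-3-(trifluoromethyl)phenyl ring gives a 1.6-fold lower number from compound 2 to compound 3 (0.22 log units; within the scatter), so in this assay this position accepts that extra nitrogen and its hydrogen-bond donor without a change that can be told from the scatter. The same holds against the compound without the chloro, with a 1.2-fold higher number from compound 1 to compound 3 (0.09 log units; within the scatter), so compound 3 cannot be separated from either neighbour, even though those two neighbours differ from each other by more than the scatter. Nothing measured here explains this reading.

Going by these compounds, whether a methylene or an ether oxygen in the place of that amino group would read the same remains open. So does the reading of the amino link on a 3-(trifluoromethyl)phenyl ring without the chloro, which would separate the two changes.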